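This account rests on a few compounds, and the source may have more. Where it says the series, first, only, none or still open, it means among the compounds named here.

Series notes. Compound 1 `CCc1nc(-c2ccc(OC(F)(F)F)cc2OC)c(CC)nc1NC(CC)CC`, compound 2 `CCc1nc(-c2ccc(OC(C)C)cc2OC)c(CC)nc1NC(CC)CC` and compound 3 `CCOc1ccc(-c2nc(CC)c(NC(CC)CC)nc2CC)c(OC)c1` share one core and differ only in the group carried on the oxygen of the aromatic ring. In an assay on IMR-32 cells for displacement of a labelled ligand from corticotropin-releasing factor receptor 1 (Homo sapiens), read by scintillation counting, with a stated time of 2 h (on this read-out higher numbers stand for weaker inhibition and lower numbers for stronger inhibition), compound 1 gives 7.2 nM, compound 2 gives 4.2 nM, and compound 3 gives 7.8 nM. Of the three numbers compound 3 carries the highest, yet a 1.1-fold higher number from compound 1 to compound 3 (0.03 log units; within the scatter) and a 1.9-fold higher number from compound 2 to compound 3 (0.27 log units; within the scatter) both lie within the scatter, as does a 1.7-fold lower number from compound 1 to compound 2 (0.23 log units; within the scatter); the three values cannot be told apart.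

Compound 4 `CCc1nc(-c2ccc(C(F)(F)F)cc2OC)c(CC)nc1NC(CC)CC` has not yet been measured. It differs from compound 3 by trifluoromethyl in place of ethoxy on an aromatic carbon. Going by the values given here, none of the measured steps bears on this directly: each exchanges one group on that oxygen for another and leaves the oxygen in place, and all three stay within the scatter. Among the compounds with values here, no step speaks to the loss of the oxygen itself, so the expectation rests on the quiet behaviour of that position alone, with some allowance for a higher number. In this assay compound 4 is estimated at 11 nM, range 3.5 nM to 35 nM. The step this estimate implies is expected to be a 1.4-fold higher number from compound 3 to compound 4 (0.15 log units; within the scatter).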

Compound 4, inhibition constant: 5.6 nM
Compound 4: middle estimate off by 2.0-fold (0.29 log units), on the high side; low and high end bracket the measured number.
By their numbers in this assay, from the lowest: compounds 2, 4, 1 and 3 (each within the scatter of the next).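

Taking the oxygen out and setting trifluoromethyl directly on the aromatic carbon leaves the numbers in this assay within the scatter of each compound carrying an oxygen-linked group at this position (a 1.4-fold lower number from compound 3 to compound 4 (0.14 log units; within the scatter)), (a 1.3-fold higher number from compound 2 to compound 4 (0.12 log units; within the scatter)) and (a 1.3-fold lower number from compound 1 to compound 4 (0.11 log units; within the scatter)). The earlier steps shown here only exchanged the group on that oxygen, whereas these show that, across compounds 1 to 4, the oxygen can be lost with no difference that can be told from the scatter. Nothing at hand bears on why this exchange leaves the numbers indistinguishable.

Open, on these data alone, is how this position responds to groups of another kind, such as an amine, a carboxylic acid or a longer chain like butoxy, or to plain hydrogen. The methoxy group and the shared core stay the same in all four compounds, so changes there remain unaddressed.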